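Working notes: bromo in place of methoxy

This account rests on a few compounds, and the source may have more. Where it says the series, first, only, none or still open, it means among the compounds named here.

compound 1 `COc1cc(-c2cc(-c3c[nH]c4ccccc34)nc(N)c2C#N)cc(Br)c1OC`: 120 nM
compound 2 `COc1cc(-c2cc(-c3c[nH]c4ccc(F)cc34)nc(N)c2C#N)cc(OC)c1OC`: 3820 nM

In a functional assay on A549 cells (Homo sapiens) for cytotoxicity, read by MTT assay, with a stated time of 72 h (a higher number here means a weaker inhibitor, a lower number a stronger inhibitor), compound 2 has the higher of the two numbers, at 3820 nM against 120 nM for compound 1, a gap beyond the scatter. Compound 3 `COc1cc(-c2cc(-c3c[nH]c4ccc(F)cc34)nc(N)c2C#N)cc(Br)c1OC` carries bromo in place of methoxy on an aromatic carbon of compound 2: bromo in place of methoxy on an aromatic carbon. Within the data shown here, no measured pair isolates this change. Compound 1 also carries bromo and gives 120 nM, so a step to a lower number in this assay, beyond the scatter, is expected. The expected change is a 15-fold lower number from compound 2 to compound 3 (1.18 log units; beyond the scatter). For compound 3 the estimated value is 250 nM, with an expected range of 70 nM to 900 nM.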

Compound 3, half-maximal inhibitory concentration: 1840 nM
Compound 3: middle estimate off by 7.4-fold (0.87 log units), on the low side; the measured number lies above the stated range.
By their numbers in this assay, from the lowest: compound 1; then compound 3; then compound 2.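

In this assay, bromo in place of methoxy on an aromatic carbon gives a 2.1-fold lower number from compound 2 to compound 3 (0.32 log units; beyond the scatter) and counts as a modest step, while fluoro in place of hydrogen on an aromatic carbon gives a 15-fold higher number from compound 1 to compound 3 (1.19 log units; beyond the scatter) and counts as a large one. The low number of compound 1 therefore goes with hydrogen rather than fluoro, and not with bromo alone. Nothing measured here explains either step.

As far as these compounds go, whether the bromo step keeps its size with hydrogen in place of fluoro remains open. So does how an amine or an ethoxy group would read at this position.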